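Fluoro to trifluoromethyl in the 3-fluorobenzyl series

This account rests on a few compounds, and the source may have more. Where it says the series, first, only, none or still open, it means among the compounds named here.

Measured in a functional assay on U-251 cells (Homo sapiens) for antiproliferative activity, read by MTT assay, with a stated time of 24 h; a higher number here means a weaker inhibitor, a lower number a stronger inhibitor
- compound 1 `C=CCOc1ccc2c(=O)c(-c3cc(OC)c(OC)cc3OC)coc2c1` gives 5900 nM
- compound 2 `C#CCOc1ccc2c(=O)c(-c3cc(OC)c(OC)cc3OC)coc2c1` gives 6450 nM
- compound 3 `COc1cc(OC)c(-c2coc3cc(OCc4cccc(F)c4)ccc3c2=O)cc1OC` gives 3510 nM

Compound 3 does not separate from the other two compounds. The data show a 1.7-fold lower number from compound 1 to compound 3 (0.23 log units; within the scatter) and a 1.8-fold lower number from compound 2 to compound 3 (0.26 log units; within the scatter) and both stay within the scatter, as does a 1.1-fold higher number from compound 1 to compound 2 (0.04 log units; within the scatter) on exchanging the two short chains.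

Compound 4 `COc1cc(OC)c(-c2coc3cc(OCc4cccc(C(F)(F)F)c4)ccc3c2=O)cc1OC` keeps the shared core and changes only the 3-fluorobenzyl end to 3-(trifluoromethyl)benzyl. The difference is trifluoromethyl in place of fluoro on an aromatic carbon and it amounts to trifluoromethyl in place of fluoro on an aromatic carbon, meta to a large group.

Among the measured compounds shown here, no measured step changes a group on this aromatic ring, so the evidence is indirect. The closest guides are the two steps ending at compound 3, where a 3-fluorophenyl replaced a much smaller group on the same chain carbon and the values stayed within the scatter. A smaller edit on that phenyl is therefore not expected to do more in this assay in either direction. The expected step is a 1.0-fold lower number from compound 3 to compound 4 (0.00 log units; within the scatter) and this is not expected to exceed the scatter. The estimate for compound 4 is 3500 nM (expected range 1800 nM to 6800 nM).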

Compound 4, half-maximal inhibitory concentration: > 10000 nM
Compound 4: only a limit was reported; the forecaster's own chance of this, stated with the estimate: 3%; middle value at least 2.8-fold (0.45 log units) from the limit.
By their numbers in this assay, from the lowest: compounds 3, 1 and 2 (each within the scatter of the next). At a limit, above all of these: compound 4.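

In this assay, among the compounds shown here, the substituent on the benzyl ring proves to matter: trifluoromethyl in place of fluoro on an aromatic carbon, meta to a large group, gives an at least 2.8-fold higher number from compound 3 to compound 4 (0.45 log units; beyond the scatter), the only step that is beyond the scatter. The exchanges among the two short chains and the 3-fluorobenzyl end had all stayed within the scatter, so this small edit on the ring does more than the larger replacements at the chain carbon. Against the short chains the reading is weaker, with an at least 1.6-fold higher number from compound 1 to compound 4 (0.22 log units; that floor lies within the scatter) and an at least 1.5-fold higher number from compound 2 to compound 4 (0.19 log units; that floor lies within the scatter), so only the comparison with the 3-fluorobenzyl compound is secure, and compound 4 is known only as a limit of the assay: the limit of > 10000 nM in this assay, at which 1 of the 4 values shown sits.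

Going by these compounds, the true value of compound 4 stays open, and with it the full size of all three steps. Also open, on these data alone, is whether this loss belongs to trifluoromethyl alone or would also appear with a chloro, methyl or methoxy group on the same aromatic carbon, or with an amine or a carboxylic acid there.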